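Sulfonamide to cyclopentyl amide on the urea aryl

This account rests on a few compounds, and the source may have more. Where it says the series, first, only, none or still open, it means among the compounds named here.

Compound 1 `O=C(Nc1cccc(-c2nc(-c3ccc(NC(=O)c4cccnc4)cc3Cl)no2)c1)Nc1cccc(C(F)(F)F)c1` and compound 2 `CS(=O)(=O)Nc1ccc(NC(=O)Nc2cccc(-c3nc(-c4ccc(NC(=O)c5cccnc5)cc4Cl)no3)c2)cc1C(F)(F)F` share one core. In a functional assay on MDA-MB-231 cells (Homo sapiens) for antiproliferative activity, read by MTT assay, with a stated time of 72 h (on this read-out higher numbers stand for weaker inhibition and lower numbers for stronger inhibition), compound 1 gives 1900 nM; in this assay compound 2 gives 700 nM, the lower of the two numbers, with a step of a 2.7-fold lower number from compound 1 to compound 2 (0.43 log units; beyond the scatter) between them. Compound 3 `O=C(Nc1cccc(-c2nc(-c3ccc(NC(=O)c4cccnc4)cc3Cl)no2)c1)Nc1ccc(NC(=O)C2CCCC2)c(C(F)(F)F)c1` differs from compound 2 by cyclopentylcarbonyl in place of methylsulfonyl on a nitrogen on an aromatic ring. No measured step exchanges one substituent on that nitrogen for another; the one step shown, hydrogen against methanesulfonamido, does not bear directly on this change. A step of a 1.2-fold lower number from compound 2 to compound 3 (0.07 log units; within the scatter) in this assay is therefore expected, within the scatter. Compound 3 is estimated at 600 nM, range 200 nM to 1800 nM.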

Compound 3, half-maximal inhibitory concentration: 300 nM
Compound 3: the middle estimate sits 2.0-fold (0.30 log units) above what was measured, and the stated range covers the measured number.
By their numbers in this assay, from the lowest: compound 3; then compound 2; then compound 1.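

In this assay the group on the nitrogen on an aromatic ring matters, not only the presence of a substituted nitrogen: cyclopentylcarbonyl in place of methylsulfonyl gives a 2.3-fold lower number from compound 2 to compound 3 (0.37 log units; beyond the scatter) beyond the scatter. Set against the hydrogen of compound 1, (cyclopentylcarbonyl)amino gives a 6.3-fold lower number from compound 1 to compound 3 (0.80 log units; beyond the scatter) and is thus a second substituent at this aromatic carbon to lower the number. No evidence on the cause of these steps is available.

Open, as far as these compounds go, is how an acetyl or cyclohexylcarbonyl group on that nitrogen would compare with cyclopentylcarbonyl, and so whether the five-membered ring matters.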